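This account rests on a few compounds, and the source may have more. Where it says the series, first, only, none or still open, it means among the compounds named here.

In an ADME assay on BJ cells (Homo sapiens) for cytotoxicity, read by CellTiter-Glo and resazurin assay, with a stated time of 72 h (a higher number here means that more compound is needed for the effect, a lower number that less compound is needed), compound 2 `CC(=O)c1cccc(-c2ccc(C(=O)N(Cc3cccc(OCCCCCC(=O)O)c3)C(C)C)cc2)c1` gives only a limit of the assay, > 26000 nM. Compound 1 `CC(C)N(Cc1cccc(OCCCCCC(=O)O)c1)C(=O)c1ccc(-c2cccc(N(C)C)c2)cc1` likewise reaches only a limit there, > 26000 nM. Compound 3 `CC(C)N(Cc1cccc(OCCCCCC(=O)O)c1)C(=O)c1ccc(-c2ccc3c(c2)OCCO3)cc1` also stops at a limit, > 21900 nM. Compound 2 thus stands with the other two at the edge of what this assay reports, as the limit of > 26000 nM in this assay, at which 2 of the 3 values shown sit, and the limit of > 21900 nM in this assay, at which 1 of the 3 values shown sits, show. Compound 4 `CC(C)N(Cc1cccc(OCCCCCC(=O)O)c1)C(=O)c1ccc(-c2cccc(OC(F)(F)F)c2)cc1` differs from compound 2 by trifluoromethoxy in place of acetyl on an aromatic carbon. The steps that might bear on it, a step that the two limits leave unreadable from compound 1 to compound 2 and a step that the two limits leave unreadable from compound 2 to compound 3, cannot be read, so no size or direction can be drawn from them; the other changes at the same part of the shared core left every value at a limit. Compound 4 is therefore expected to behave alike, with an expected step of a number no higher from compound 2 to compound 4 (the limit leaves the size open). Compound 4 is estimated at 26000 nM, within 12000 nM to 60000 nM.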

Compound 4, half-maximal effective concentration: > 26000 nM
Compound 4: only a limit was reported; the forecaster's own chance of this, stated with the estimate: 85%; the middle value sits exactly at the limit.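

Among the compounds shown here, compound 4, like compounds 1, 2 and 3, stops at a limit, so no step from any of them to compound 4 can be read. From the compounds shown here alone, whether these four compounds differ at all in this assay, and in which direction, stays open.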